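Swapping Pyrazolyl for Indolyl: Expected Cytotoxicity of Compound 4

The compounds below may be only part of what the source reports. "The series", "measured", "known", "first", "only" and "open" are said of these compounds alone.

Of the compounds shown here, three sharing one core have been measured in an ADME assay on BaF3 cells (Mus musculus) for cytotoxicity; a higher number here means that more compound is needed for the effect, a lower number that less compound is needed. Compound 1 `Nc1cccc(-c2cc(Nc3ccc(OC(F)(F)F)cc3)ncn2)c1` gives only a limit of the assay, > 10000 nM. Compound 2 `FC(F)(F)Oc1ccc(Nc2cc(-n3ccnc3)ncn2)cc1` likewise gives only a limit, > 10000 nM. Compound 3 `FC(F)(F)Oc1ccc(Nc2cc(-c3cn[nH]c3)ncn2)cc1` also reaches only a limit, > 10000 nM. On the numbers shown, compound 3 therefore stands at the limit together with the other two, and the steps a step that the two limits leave unreadable from compound 1 to compound 3 and a step that the two limits leave unreadable from compound 2 to compound 3 cannot be read, as the limit of > 10000 nM in this assay, at which 3 of the 3 values shown sit, records. Compound 4 `FC(F)(F)Oc1ccc(Nc2cc(-c3ccc4[nH]ccc4c3)ncn2)cc1` differs from compound 3 by 1H-indol-5-yl in place of 1H-pyrazol-4-yl on an aromatic carbon. The measured steps that bear on this change, those leading into the pyrazolyl compound, were all unreadable, so neither a size nor a direction can be drawn from them. In this assay the expected result is that compound 4 again reaches only the limit, an estimated step that the limit leaves unreadable from compound 3 to compound 4. Compound 4 is thus estimated at 15000 nM, with a range from 5000 nM to 50000 nM.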

Compound 4, half-maximal effective concentration: > 10000 nM
Compound 4 gave a limit, no number; the forecaster's own chance of this, stated with the estimate: 80%; the middle value is on the limit's open side.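

In this assay compound 4 gives > 10000 nM as a limit of the assay, so its steps from compound 1, compound 2 and compound 3 cannot be read: the limit of > 10000 nM in this assay, at which 4 of the 4 values shown sit.

The compounds shown leave open whether the groups exchanged on the shared core differ at all in this read-out.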